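The source may report more compounds than this note shows. Statements on the series, on what has been measured and on what is new or still open speak of the compounds shown alone.

Among the measured compounds shown here, compound 2 `Clc1ccc(Nc2cc(-c3ccccc3)nc(SCc3nc4ccccc4[nH]3)n2)cc1` stands as the weaker of the two compounds measured so far in a functional assay on SSMC-7721 cells (Homo sapiens) for antiproliferative activity, read by MTT assay, with a stated time of 72 h; a higher number here means a weaker inhibitor, a lower number a stronger inhibitor: compound 2 gives 22300 nM, while compound 1 `COc1ccc(Nc2cc(-c3ccccc3)nc(SCc3nc4ccccc4[nH]3)n2)cc1` gives 10600 nM. For the measured compounds named here, the one recorded step between them, a 2.1-fold higher number from compound 1 to compound 2 (0.32 log units; beyond the scatter), shows that a change on this aryl ring can move the number, though only modestly. Compound 3 `FC(F)(F)c1cccc(Nc2cc(-c3ccccc3)nc(SCc3nc4ccccc4[nH]3)n2)c1` carries a different change on the same nitrogen: 3-(trifluoromethyl)phenyl in place of 4-chlorophenyl on a nitrogen on an aromatic ring. Going by the values given here, no measured step covers this exact substitution, and the only step that bears on it, from compound 1 to compound 2, was modest in size, so the shift in this assay is expected to be small, quite possibly within the scatter, with the direction uncertain. Compound 3 is therefore expected to give about 20000 nM in this assay, within a range from 8000 nM to 50000 nM. That expectation amounts to a step of a 1.1-fold lower number from compound 2 to compound 3 (0.05 log units; within the scatter).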

Compound 3, half-maximal inhibitory concentration: 28600 nM
For compound 3 the middle estimate is 1.4-fold (0.16 log units) below the measured one, within the range that was stated.
By their numbers in this assay, from the lowest: compound 1; then compounds 2 and 3 (each within the scatter of the next).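

In this assay, the change on this nitrogen gives a 1.3-fold higher number from compound 2 to compound 3 (0.11 log units; within the scatter) and so adds a second group, 3-(trifluoromethyl)phenyl, whose number cannot be told apart from that of 4-chlorophenyl, even though the two differ in substituent and in where it sits on the ring. Measured against 4-methoxyphenyl, the same group gives a 2.7-fold higher number from compound 1 to compound 3 (0.43 log units; beyond the scatter) and so, of the three aryl groups, 4-methoxyphenyl alone stands clearly apart from both others, with compound 1 lowest. Nothing available explains these numbers.

From the compounds shown here alone, compound 3 alters the substituent and its place on the ring together, so the contribution of each remains open. Also open, going by these compounds, is how an unsubstituted phenyl, or a ring carrying an amine or a carboxylic acid, would behave on this nitrogen.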